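The source may hold more compounds than are shown below. What is called first, only, known or untested is meant among the compounds shown, and "the series" means these compounds.

Working notes on the series. Three compounds of the shared core are measured in an assay on isolated protein (Mus musculus) for inhibition of IL15-IL15 receptor (Homo sapiens), read by resazurin assay, with stated times of 30 min and 2.5 days; on this read-out lower numbers stand for stronger inhibition and higher numbers for weaker inhibition. Compound 1 `CN(C(=O)CSc1nnc(Cc2nn(C)c(=O)c3ccccc23)n1C)c1ccc(Cl)cc1Cl` reaches only a limit of this assay, > 30000 nM. Compound 2 `Cn1c(Cc2nn(C)c(=O)c3ccccc23)nnc1SCCCCCCCCCCC(=O)Nc1ccccc1Cl` gives 15000 nM, and compound 3 `Cn1c(Cc2nn(C)c(=O)c3ccccc23)nnc1S(=O)(=O)CCCCCCCC(=O)Nc1ccc(Br)cc1Br` gives 1400 nM. Of the two numbers, compound 2 stands at the higher one; its gap to compound 3 lies beyond the scatter, and the remaining value is a limit only, as the limit of > 30000 nM in this assay, at which 1 of the 3 values shown sits, records.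

Compound 4 `CCCCCCCCCCSc1nnc(Cc2nn(C)c(=O)c3ccccc23)n1C` is not yet measured. It differs from compound 2 by hydrogen in place of (2-chlorophenyl)carbamoyl on a saturated chain carbon, ten or more bonds along the chain from a sulfur. Going by the values given here, no measured pair isolates this change, so the expectation rests on compound 2 alone. The step from compound 2 to compound 4 is expected to run toward weaker inhibition, a 2.3-fold higher number from compound 2 to compound 4 (0.37 log units; beyond the scatter), possibly beyond the scatter. Compound 4 is thus expected at about 35000 nM, with a range from 10000 nM to 120000 nM, and a fair chance that only a limit is reported.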

Compound 4, half-maximal inhibitory concentration: 7600 nM
Beside the measured number, compound 4's estimate is 4.6-fold (0.66 log units) above it, outside the stated range (below it).
By their numbers in this assay, from the lowest: compound 3; then compounds 4 and 2 (each within the scatter of the next). At a limit, above all of these: compound 1.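

Hydrogen in place of (2-chlorophenyl)carbamoyl, on a saturated chain carbon, gives a 2.0-fold lower number from compound 2 to compound 4 (0.30 log units; within the scatter) in this assay. This first single-place pair shows that the whole aromatic amide end of the chain can be replaced by hydrogen without a change beyond the scatter. No recorded measurement explains this step.

On these data alone, it remains open whether a carboxylic acid or an amine at the chain end, or a longer chain, would shift the number beyond the scatter. As far as these compounds go, the same replacement on the sulfonyl-linked chain of compound 3 also remains open.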